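A few compounds are considered here, and "the series" means these few. Any claim that something is new, unique, unknown or untested is made for them only; others in the source may bear on it.

Measured compounds: compound 1 `CC(C)(C)N(NC(=O)c1ccccc1Cl)C(=O)c1ccccc1Cl` with 331 nM; compound 2 `CC(C)(C)N(NC(=O)c1ccc(Cl)cc1)C(=O)c1ccccc1Cl` with 115 nM.

Compound 1 stands highest of the two numbers in an assay on cells for agonist activity at ecdysone receptor (Bombyx mori), read by a luciferase reporter, with a stated time of 24 h; a higher number here means that more compound is needed for the effect, a lower number that less compound is needed; its nearest neighbour is compound 2, and the step of a 2.9-fold lower number from compound 1 to compound 2 (0.46 log units; beyond the scatter) runs downward, beyond the scatter. Compound 3 `CCc1ccc(C(=O)NN(C(=O)c2ccccc2Cl)C(C)(C)C)cc1` is not yet measured. It differs from compound 1 by 4-ethylphenyl in place of 2-chlorophenyl on a carbonyl carbon, so the 2-chlorophenyl on the carbonyl carbon is again exchanged, as in compound 2, but here for a 4-ethylphenyl rather than a 4-chlorophenyl. Among the measured compounds shown here, the only step that bears on this is the one from compound 1 to compound 2, which was modest and downward. For the measured compounds named here, no measured pair covers the exchange of chlorine for ethyl itself, so the expectation rests on that single step alone. For compound 3 a step of about a 3.7-fold lower number from compound 1 to compound 3 (0.57 log units; beyond the scatter) is expected, downward and beyond the scatter, giving an estimated 90 nM with a range from 25 nM to 300 nM.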

Compound 3, half-maximal effective concentration: 5.75 nM
Beside the measured number, compound 3's estimate is 16-fold (1.19 log units) above it; the whole stated range lies above it.
By their numbers in this assay, from the lowest: compound 3; then compound 2; then compound 1.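

In this assay the exchange of 2-chlorophenyl for 4-ethylphenyl on a carbonyl carbon gives a 58-fold lower number from compound 1 to compound 3 (1.76 log units; beyond the scatter) as a large step, whereas the exchange for 4-chlorophenyl gave only a modest one. Leaving 2-chlorophenyl therefore does not account for the whole change at this position, and the group on the aromatic carbon also matters: ethyl in place of chloro gives a 20-fold lower number from compound 2 to compound 3 (1.30 log units; beyond the scatter) in its own right. Nothing at hand explains the difference between ethyl and chloro here.

As far as these compounds go, whether a longer chain such as propyl, or a methoxy group or an amine, on that same aromatic carbon would extend or reverse this step remains open. From the compounds shown here alone, the 2-chlorophenyl on the other carbonyl carbon is common to all three compounds, so its contribution also remains unknown.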